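The compounds below may be only part of what the source reports. "The series", "measured", "known", "first", "only" and "open" are said of these compounds alone.

Two compounds have numbers in a functional assay on the whole organism (strain Sprague-Dawley CD) for inhibition, with Rattus norvegicus as the target, read by paw edema, at a dose of 30 mg/kg by the intraperitoneal route; on this read-out higher numbers stand for a stronger effect at the one dose given and lower numbers for a weaker effect. Compound 1 `COC(=O)C(=O)Nc1ccc(OC)c(=O)cc1` gives 36%. Compound 2 `CCOC(=O)C(=O)Nc1ccccc(Oc2ccccc2)c1=O` gives 16%, the lowest of the two, with compound 1 standing higher by more than the scatter. Compound 3 `CCOC(=O)C(=O)Nc1ccccc(OC)c1=O` has not been measured; it differs from compound 2 by methyl in place of phenyl on an oxygen on an aromatic ring. Going by the values given here, compound 1 also carries the methoxy, but differs from compound 2 in a second place as well, so no single measured step covers this change. A moderate increase is nonetheless expected, a number 12 percentage points higher from compound 2 to compound 3 (beyond the scatter), in this assay. Compound 3 is expected to give 28%, within 10% to 45%.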

Compound 3, a percentage reported as inhibition, in the whole organism at one dose (the size of the read-out at that dose, not a potency): 52%
Compound 3: middle estimate off by 24 percentage points, on the low side; the measured number lies above the stated range.
By their numbers in this assay, from the lowest: compound 2; then compound 1; then compound 3.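

In this assay the step is a number 36 percentage points higher from compound 2 to compound 3 (beyond the scatter) and is large, so the group on this oxygen matters strongly to the read-out at the one dose given. Compound 1 could not show this, since it differs from compound 2 in a second place as well. Nothing measured here bears on why the phenoxy to methoxy change has this effect.

Still open, on these data alone, is whether a propyl chain or a free hydroxyl at this place would stand nearer to compound 3 or to compound 2. Also open, as far as these compounds go, is whether the step carries over to the core of compound 1.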